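Chain shortening with hydroxy on the thioether substituent

The compounds below may be only part of what the source reports. "The series", "measured", "known", "first", "only" and "open" are said of these compounds alone.

Compound 2 `CCCCSc1nc2c(N)ncnc2n1[C@@H]1O[C@H](COP(=O)(O)OP(=O)(O)OP(=O)(O)O)[C@@H](O)[C@H]1O` stands lowest of the two numbers in an assay (strain Sprague-Dawley) for inhibition of GTP:AMP phosphotransferase AK3, mitochondrial (Rattus norvegicus), using Lineweaver-Burk analysis (on this read-out higher numbers stand for weaker inhibition and lower numbers for stronger inhibition), where compound 2 gives 60000 nM; its nearest neighbour is compound 1 `CSc1nc2c(N)ncnc2n1[C@@H]1O[C@H](COP(=O)(O)OP(=O)(O)OP(=O)(O)O)[C@@H](O)[C@H]1O`, which in this assay gives 360000 nM. Within the data shown here, the one measured step, a 6.0-fold lower number from compound 1 to compound 2 (0.78 log units; beyond the scatter), shows that lengthening the chain on the sulfur lowered the number. Compound 3 `Nc1ncnc2c1nc(SCCO)n2[C@@H]1O[C@H](COP(=O)(O)OP(=O)(O)OP(=O)(O)O)[C@@H](O)[C@H]1O` differs from compound 2 by hydroxy in place of ethyl on a saturated chain carbon, two bonds along the chain from a sulfur. Among the measured compounds shown here, this change cuts the chain back while a hydroxy enters; no measured pair shows what the hydroxy does on its own. Given the direction of a 6.0-fold lower number from compound 1 to compound 2 (0.78 log units; beyond the scatter) the step is expected to raise the number. Part of the chain remains, and a rise smaller than a 6.0-fold lower number from compound 1 to compound 2 (0.78 log units; beyond the scatter) is expected. For compound 3 the expected step is a 2.5-fold higher number from compound 2 to compound 3 (0.40 log units; beyond the scatter). Compound 3 is estimated at 150000 nM in this assay. The range expected for compound 3 runs from 60000 nM to 400000 nM.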

Compound 3, inhibition constant: 220000 nM
Compound 3: the middle estimate sits 1.5-fold (0.17 log units) below what was measured, within the range that was stated.
By their numbers in this assay, from the lowest: compound 2; then compounds 3 and 1 (each within the scatter of the next).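

In this assay, the lower number that came with butyl on the sulfur does not carry over to the 2-hydroxyethyl chain: a 3.7-fold higher number from compound 2 to compound 3 (0.56 log units; beyond the scatter). Set against the shortest chain, the hydroxy-bearing chain shows no separable difference: a 1.6-fold lower number from compound 1 to compound 3 (0.21 log units; within the scatter). Across these three compounds, then, only the butyl chain stands clear of the others, and no measurement on hand offers an explanation for this.

Still open, as far as these compounds go, is whether the rise follows from the shorter chain or from the hydroxy itself; a plain ethyl chain on the sulfur would separate the two. Also open, from the compounds shown here alone, is how a chain longer than butyl, or an amine in place of the hydroxy, would read in this assay.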